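The source may report more compounds than this note shows. Statements on the series, on what has been measured and on what is new or still open speak of the compounds shown alone.

Measured compounds:
- compound 1 `O=C(Nc1ccc(S(=O)(=O)Nc2ccccc2)cc1)c1cc(F)c(Cl)cc1F` gives 37%
- compound 2 `CN(c1ccccc1)S(=O)(=O)c1ccc(NC(=O)c2ccc(Cl)cc2Cl)cc1` gives 50%

Both values come from a functional assay on HEK293 cells for agonist activity at probable G-protein coupled receptor 27 (Homo sapiens), read by a luciferase reporter and beta-arrestin recruitment, with a stated time of 10 min (on this read-out higher numbers stand for larger maximal responses and lower numbers for smaller maximal responses), in which compound 1 gives 37% and compound 2 gives 50%. Compound 1 stands lowest of the two, and compound 2 sits above it by a gap beyond the usual scatter. The two compounds differ in more than one place, so their values show only where each lands, not what any single change does.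

Compound 3 `Cc1cc(Cl)ccc1C(=O)Nc1ccc(S(=O)(=O)Nc2ccccc2)cc1` has not been measured. It differs from compound 1 in one place: 4-chloro-2-methylphenyl in place of 4-chloro-2,5-difluorophenyl on a carbonyl carbon. Among the measured compounds shown here, no measured pair isolates this kind of exchange, so there is no direct guide. The expectation is a small rise in maximal response, with the step of a number 8 percentage points higher from compound 1 to compound 3 (within the scatter) likely near or just beyond the scatter. Compound 3 is therefore estimated at 45%, in the range 25% to 65%.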

Compound 3, largest response reached (Emax), in percent of the reference or control that the assay uses: 123%
The estimate for compound 3 lay 78 percentage points below the measured number; the measured number lies above the stated range.
By their numbers in this assay, from the lowest: compound 1; then compound 2; then compound 3.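

In this assay, the group on the carbonyl carbon turns out to matter greatly for the largest response reached: with the rest of the molecule unchanged, putting 4-chloro-2-methylphenyl in place of 4-chloro-2,5-difluorophenyl gives a number 86 percentage points higher from compound 1 to compound 3 (beyond the scatter), a large step. The earlier compounds shown here could not show this, since they differ in more than one place and so isolate no single change. Nothing available here explains why this exchange has so large an effect.

The exchange removes the fluorine atoms and adds the methyl in a single step, so the share of each in the rise remains unresolved. Going by these compounds, whether a methoxy group or an amine in place of that methyl would keep the high response also remains open.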